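Adding a dithioester arm to a limit-bound enaminone

A few compounds are considered here, and "the series" means these few. Any claim that something is new, unique, unknown or untested is made for them only; others in the source may bear on it.

The compounds here share a small six-membered non-aromatic carbon ring carrying an enaminone and two methyl groups, with an aniline attached. Compound 2 `CC1(C)CC(=O)C=C(Nc2ccc(Cl)cc2)C1` carries a chloro on the aromatic ring, and in a functional assay on PBMC cells (Homo sapiens) for inhibition, read by ELISA, with a stated time of 18 h (on this read-out higher numbers stand for weaker inhibition and lower numbers for stronger inhibition), compound 2 gives only a limit, > 20 ug/mL. Compound 3 `CC1(C)CC(=O)C=C(Nc2ccc(Br)cc2)C1` carries a bromo instead, and in this assay compound 3 likewise gives only a limit, > 20 ug/mL. Among the compounds with values here, the one measured step, a step that the two limits leave unreadable from compound 2 to compound 3, therefore cannot be sized, since both ends sit at the same limit (the limit of > 20 ug/mL in this assay, at which 2 of the 3 values shown sit). Compound 1 `CC(=O)OC[C@H]1O[C@@H](SC(=S)C2=C(Nc3ccc(Cl)cc3Cl)CC(C)(C)CC2=O)[C@H](OC(C)=O)[C@@H](OC(C)=O)[C@H]1OC(C)=O`, which carries a dithioester attached through a protected sugar, gives a number in this assay, 2.1 ug/mL.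

Compound 4 `CC1(C)CC(=O)C(C(=S)SCCO)=C(Nc2ccc(Br)cc2)C1` differs from compound 3 by a group of 6 heavy atoms (3 carbon, 1 oxygen, 2 sulfur; no ring) in place of a hydrogen atom, on a double-bonded ring carbon. Within the data shown here, no measured step covers this change, so the expectation rests on the contrast between compound 1 and compound 3, where only compound 1 returns a number. Compound 4 is expected to reach 6 ug/mL, within 1.5 ug/mL to 20 ug/mL, meaning an estimated step of an at least 3.3-fold lower number from compound 3 to compound 4 (0.52 log units; beyond the scatter).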

Compound 4, half-maximal inhibitory concentration: > 20 ug/mL
Compound 4: no number, only a limit (the forecaster's own chance of this, stated with the estimate: 35%); middle value at least 3.3-fold (0.52 log units) from the limit.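

Compound 3 and compound 4 both give only a limit in this assay, so the size of the step between them cannot be read: the limit of > 20 ug/mL in this assay, at which 3 of the 4 values shown sit.

The compounds shown leave open which part of the structure of compound 1 goes with its measured value of 2.1 ug/mL.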